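The compounds below may be only part of what the source reports. "The series", "measured", "known", "first", "only" and "open" are said of these compounds alone.

The shared core appears in compound 1, `CC(C(=O)NCc1ccc(C(C)(C)C)cc1)c1ccc(NS(C)(=O)=O)c(Cl)c1`, and the three measured compounds were compared in an assay on CHO cells for displacement of a labelled ligand from transient receptor potential cation channel subfamily V member 1 (Rattus norvegicus), read by scintillation counting, with a stated time of 60 min; a higher number here means a weaker inhibitor, a lower number a stronger inhibitor. Compound 1 gives 30.7 nM. Compound 2, `CC(C(=O)NCc1ccc(C(C)(C)C)cc1)c1ccc(NS(C)(=O)=O)c(Br)c1`, gives 7.4 nM, and compound 3, `CC(C(=O)NCc1ccc(C(C)(C)C)cc1)c1cc(F)c(NS(C)(=O)=O)c(F)c1`, gives 19.9 nM. Compound 2 stands lowest of the three numbers and so binds most strongly here: compound 3 sits above it by a margin beyond the scatter, and compound 1 further still. Going by the values given here, the only single-point step among them, a 4.1-fold lower number from compound 1 to compound 2 (0.62 log units; beyond the scatter), shows that exchanging one halogen for another at this spot on the core already shifts the number clearly.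

Compound 4, `CC(C(=O)NCc1ccc(C(C)(C)C)cc1)c1ccc(NS(C)(=O)=O)c(N2CCCCC2)c1`, moves on from compound 2 in one place: piperidin-1-yl in place of bromo on an aromatic carbon. Among the compounds with values here, the incoming group is much larger than the bromine it replaces and is not a halogen, so no measured step addresses this exchange directly; the halogen swap from compound 1 to compound 2 only tells that the spot is sensitive to what occupies it. Within the data shown here, with no closer precedent, the expectation is that the number rises rather than falls, by a modest to sizeable amount. Compound 4 is therefore expected to give 60 nM, with a range from 10 nM to 400 nM, which corresponds to an expected step of an 8.1-fold higher number from compound 2 to compound 4 (0.91 log units; beyond the scatter).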

Compound 4, inhibition constant: "active" (no number reported)
For compound 4 the study gives words and no number; there is nothing to compare the estimate with.
By their numbers in this assay, from the lowest: compound 2; then compounds 3 and 1 (each within the scatter of the next).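

In this assay, going by these compounds alone, compound 4 is reported only as active, with no number, so no step from compound 2 to compound 4 can be read. The compounds shown leave open how far piperidin-1-yl in place of bromo moves the number, if at all. No further data here bear on this result.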